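The source may report more compounds than this note shows. Statements on the series, on what has been measured and on what is new or still open speak of the compounds shown alone.

Two compounds carry numbers in a functional assay (lung parenchyma) for displacement of a labelled ligand, with Cavia porcellus as the target; a lower number here means a stronger inhibitor, a higher number a weaker inhibitor. Compound 1 (`COc1cc(C(=O)NS(=O)(=O)c2ccccc2C)ccc1Cn1cc(C)c2ccc(C(=O)NCC3CCCC3)cc21`) gives 9.89 nM; 9.89 nM (2 entries), and compound 2 (`COc1cc(C(=O)NS(=O)(=O)c2ccccc2C)ccc1Cc1cn(C)c2ccc(NC(=O)CC3CCCC3)cc12`) gives 0.3 nM, the lower of the two values. Compound 3 (`COc1cc(C(=O)NS(=O)(=O)c2ccccc2C)ccc1Cc1cn(C)c2ccc(C(=O)NCC3CCCC3)cc12`) has the same atoms as compound 2, joined differently: (cyclopentylmethyl)carbamoyl in place of ((cyclopentylmethyl)carbonyl)amino on an aromatic carbon. The exchange sits on an aromatic carbon, with (cyclopentylmethyl)carbamoyl in place of ((cyclopentylmethyl)carbonyl)amino. Among the measured compounds shown here, no measured pair isolates this change, so its size remains uncertain. Compound 1 carries the same (cyclopentylmethyl)carbamoyl on a differently joined core and gives 9.89 nM; 9.89 nM (2 entries), which points to a moderate loss rather than a gain in this assay. The expected change is a 6.7-fold higher number from compound 2 to compound 3 (0.82 log units; beyond the scatter), towards weaker inhibition. For compound 3 the expected value is 2 nM, with an estimated range of 0.4 nM to 10 nM.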

Compound 3, inhibition constant: 3.21 nM
Estimate against measurement, compound 3: 1.6-fold (0.21 log units) below; the measured number falls inside the stated range.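

In this assay, placing (cyclopentylmethyl)carbamoyl in place of ((cyclopentylmethyl)carbonyl)amino on the aromatic carbon gives an 11-fold higher number from compound 2 to compound 3 (1.03 log units; beyond the scatter) and therefore weaker inhibition. Among the compounds shown here, this matched pair provides the first direct reading of the exchange, and it shows that this position distinguishes between two groups that have the same atoms and the same hydrogen-bond donor and acceptor counts. Nothing available here accounts for the size of this step.

From the compounds shown here alone, the core of compound 1 appears only with (cyclopentylmethyl)carbamoyl, so the size of this exchange on that core remains open. Also open, going by these compounds, is whether ((cyclopentylmethyl)carbonyl)amino keeps its advantage when cyclopentyl gives way to cyclohexyl or a straight butyl chain, or when a urea takes the place of the amide link.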